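The source may report more compounds than this note shows. Statements on the series, on what has been measured and on what is new or still open speak of the compounds shown alone.

Compound 1 `Cc1cc(CO)cc(C)c1Oc1cc(Nc2ccc(C#N)cc2)c(N)cc1CO` gives 15900 nM
Compound 2 `CC(=O)CCc1cc(C)c(Oc2cc(Nc3ccc(C#N)cc3)c(N)cc2C(F)(F)F)c(C)c1` gives 11100 nM
Compound 3 `CNC(=O)c1cc(N)c(Nc2ccc(C#N)cc2)cc1Oc1c(C)cc(CCC#N)cc1C` gives > 9100 nM (a limit)

In an ADME assay on TZM cells (Homo sapiens) for cytotoxicity, read by XTT assay, with a stated time of 4 days (a lower number here means that less compound is tolerated, a higher number that more compound is tolerated), compound 1 gives 15900 nM and compound 2 gives 11100 nM as two values within the usual scatter of each other. Compound 3 gives no number, only a limit (> 9100 nM). It is the single such case among the three (the limit of > 9100 nM in this assay, at which 1 of the 3 values shown sits).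

Compound 4 `Cc1cc(CCC#N)cc(C)c1Oc1cc(Nc2ccc(C#N)cc2)c(N)cc1C(N)=O` is compound 3 with hydrogen in place of methyl on an amide-type nitrogen, which turns methylcarbamoyl into carbamoyl (hydrogen in place of methyl on an amide-type nitrogen). Among the compounds with values here, no pair of measured compounds shows this change on its own. In this assay the expectation is therefore for no step beyond the scatter, in either direction. That expectation rests on compound 1 (15900 nM) and compound 2 (11100 nM), two relatives on the shared core. The expected change is small (a step that the limit leaves unreadable from compound 3 to compound 4). A limit instead of a number would be no surprise for compound 4. For compound 4 the estimated value is 13000 nM with an expected range from 5000 nM to 40000 nM as its ends.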

Compound 4, half-maximal cytotoxic concentration: > 9400 nM
Compound 4 ended at the assay's limit; the forecaster's own chance of this, stated with the estimate: 45%; the middle value lies beyond the limit too.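

In this assay compound 3 and compound 4 each give only a limit and no number, and the step between them cannot be read. The compounds shown leave open whether hydrogen in place of methyl on an amide-type nitrogen changes the tolerated concentration at all.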